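The source may report more compounds than this note shows. Statements on the series, on what has been measured and on what is new or still open speak of the compounds shown alone.

The measured compounds:

Compound 1, `COc1cccc(/C=C/C(=O)Nc2nc3ccccc3c(=O)s2)c1`, gives 470 nM in an in vitro assay on cells for inhibition of Amine oxidase [flavin-containing] B (Homo sapiens), read by fluorescence and Amplex Red, with stated times of 30 min and 45 min; on this read-out higher numbers stand for weaker inhibition and lower numbers for stronger inhibition.
Compound 2, `COc1cccc(/C=C/CC(=O)Nc2nc3ccccc3c(=O)s2)c1`, gives 238 nM in this assay.
Compound 3, `O=C(C/C=C/c1cccc(Cl)c1)Nc1nc2ccccc2c(=O)s1`, gives > 1000 nM in this assay; this value is a limit of the assay, not a number.

Compound 1 and compound 2 share a core but differ in more than one place, and the difference between the two cores is not broken down here. Their values lie close together: compound 1 stands at the higher of the two numbers, and the gap to compound 2 is within the usual scatter, so no order can be read from it.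

Among the compounds with values here, the one change that is measured runs from compound 2 to compound 3: chloro in place of methoxy on an aromatic carbon. The step of an at least 4.2-fold higher number from compound 2 to compound 3 (0.62 log units; beyond the scatter) is at least modest and beyond the scatter, its exact size unknown because of the limit of > 1000 nM in this assay, at which 1 of the 3 values shown sits.

Compound 4, `O=C(/C=C/c1cccc(Cl)c1)Nc1nc2ccccc2c(=O)s1`, has not yet been measured in this assay. It differs from compound 1 by chloro in place of methoxy on an aromatic carbon, which is the same change as from compound 2 to compound 3. Within the data shown here, because an at least 4.2-fold higher number from compound 2 to compound 3 (0.62 log units; beyond the scatter) was the only step of this kind seen, a weakening of similar size is expected here too. The estimate means a 5.3-fold higher number from compound 1 to compound 4 (0.73 log units; beyond the scatter) as the expected step. Compound 4 is therefore expected to give about 2500 nM in this assay, within a range from 1000 nM to 8000 nM, and the value may again fall outside the range the assay reports as a number.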

Compound 4, half-maximal inhibitory concentration: 93.3 nM
Estimate against measurement, compound 4: 27-fold (1.43 log units) above; the measured number lies below the stated range.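

In this assay, replacing methoxy with chloro on the aromatic ring gives a 5.0-fold lower number from compound 1 to compound 4 (0.70 log units; beyond the scatter), so here the chloro compound is the stronger inhibitor, the opposite of what the same swap did on the other core: the same change on two cores in this assay, an at least 4.2-fold higher number (0.62 log units; beyond the scatter) from compound 2 to compound 3 and a 5.0-fold lower number (0.70 log units; beyond the scatter) from compound 1 to compound 4, at least 21-fold (1.32 log units) apart, beyond the scatter of two such steps The effect of this change therefore does not carry over from one core to the other in this series, and even its direction cannot be assumed, though this rests on a single pair of compounds on each core and does not show which difference between the cores lies behind the reversal. The size of the earlier step also stays open-ended, as compound 3 sits at a limit of the assay rather than at a number: the limit of > 1000 nM in this assay, at which 1 of the 4 values shown sits.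

What the compounds shown leave open is how other groups in this place on the ring, such as fluoro, methyl or an amine, would behave on each core, and so whether the reversal is confined to the swap of methoxy for chloro. Also open, going by these compounds, is whether a longer chain in the linking part of the molecule would side with compound 1 and compound 4 or with compound 2 and compound 3.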